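Benzylamino series: from compound 3 to compound 4

The source may hold more compounds than are shown below. What is called first, only, known or untested is meant among the compounds shown, and "the series" means these compounds.

Measured in a functional assay on K562 cells (Homo sapiens) for antiproliferative activity, with a stated time of 72 h; a lower number here means a stronger inhibitor, a higher number a weaker inhibitor:
- compound 1 `OC[C@H]1O[C@@H](n2cnc3c(NCc4ccccc4Cl)ncnc32)[C@H](O)[C@@H]1O`: 64000 nM
- compound 2 `Cc1ccc(CNc2ncnc3c2ncn3[C@@H]2O[C@H](CO)[C@@H](O)[C@H]2O)cc1`: > 166000 nM, a limit
- compound 3 `COc1cc(CNc2ncnc3c2ncn3[C@@H]2O[C@H](CO)[C@@H](O)[C@H]2O)cc(OC)c1`: > 166000 nM, a limit

Compound 3 has no numerical value and stands at the limit of > 166000 nM in this assay, at which 2 of the 3 values shown sit. The next structure is compound 4 `OC[C@H]1O[C@@H](n2cnc3c(NCc4c(F)ccc(F)c4F)ncnc32)[C@H](O)[C@@H]1O`: 2,3,6-trifluorophenyl in place of 3,5-dimethoxyphenyl on a saturated chain carbon bound to a nitrogen on an aromatic ring.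

Among the measured compounds shown here, two measured steps bear on this change: an at least 2.5-fold higher number from compound 1 to compound 2 (0.41 log units; beyond the scatter) and an at least 2.5-fold higher number from compound 1 to compound 3 (0.41 log units; beyond the scatter). Going by these compounds, both start from the 2-chlorophenyl of compound 1 and end at a limit, so their true size remains open. The remaining measured step is a step that the two limits leave unreadable from compound 2 to compound 3, which gives no guidance. Only compound 1 carries a halogen on this ring, so the evidence for a halogen trend is thin. Compound 4 also carries halogen there, and a value near that of compound 1 at 64000 nM is expected. Another limit is quite possible for compound 4. In this assay, the expected change is an at least 1.6-fold lower number from compound 3 to compound 4 (0.22 log units; that floor lies within the scatter), towards a lower number. For compound 4 the estimated value is 100000 nM, with an expected range of 45000 nM to 230000 nM.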

Compound 4, half-maximal inhibitory concentration: > 166000 nM
Compound 4: a limit, no number; the forecaster's own chance of this, stated with the estimate: 50%; middle value at least 1.6-fold (0.22 log units) away from the limit.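

In this assay compound 4 gives > 166000 nM, a limit of the assay and not a number. Against the 2-chlorophenyl, the 2,3,6-trifluorophenyl gives an at least 2.5-fold higher number from compound 1 to compound 4 (0.41 log units; beyond the scatter), so halogen on this ring does not by itself carry the activity seen with compound 1, and compound 1 remains the only one of the set with a numerical value. The steps among compound 2, compound 3 and compound 4 cannot be read, since all three sit at one ceiling: the limit of > 166000 nM in this assay, at which 3 of the 4 values shown sit.

Going by these compounds, how far these three compounds lie past that limit stays open, as does what sets the 2-chlorophenyl apart from the 2,3,6-trifluorophenyl. Also open, on these data alone, is whether a phenyl bearing a carboxylic acid or an amine, or a longer chain at this position, would give a numerical value in this assay.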